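A few compounds are considered here, and "the series" means these few. Any claim that something is new, unique, unknown or untested is made for them only; others in the source may bear on it.

Measured in an in vitro ADME assay on microsomes from liver (Mus musculus) for pharmacokinetics, read by LC-MS, with a stated time of 10 min, tested at 1 uM; on this read-out higher numbers stand for fast clearance and lower numbers for slow clearance:
- compound 1 `CN1C[C@H](C(=O)Nc2cccc(F)c2)[C@@H](c2ccc(/C=C/C(=O)Nc3ccccc3N)cc2)C1`: 56 mL/min/kg
- compound 2 `Cc1cccc(NC(=O)[C@H]2CN(C)C[C@@H]2c2ccc(/C=C/C(=O)Nc3ccccc3N)cc2)c1`: 74 mL/min/kg
- compound 3 `CN1C[C@H](C(=O)Nc2ccccc2F)[C@@H](c2ccc(/C=C/C(=O)Nc3ccccc3N)cc2)C1`: 67 mL/min/kg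

Compound 3, at 67 mL/min/kg, lies within the scatter of both other compounds. Compound 4 `CN1C[C@H](C(=O)Nc2ccc(F)c(Br)c2)[C@@H](c2ccc(/C=C/C(=O)Nc3ccccc3N)cc2)C1` differs from it as follows: 3-bromo-4-fluorophenyl in place of 2-fluorophenyl on an amide-type nitrogen. In words, 3-bromo-4-fluorophenyl stands in place of 2-fluorophenyl on an amide-type nitrogen. The measured changes at this nitrogen are small: a 1.3-fold higher number from compound 1 to compound 2 (0.12 log units; within the scatter), a 1.2-fold higher number from compound 1 to compound 3 (0.08 log units; within the scatter) and a 1.1-fold lower number from compound 2 to compound 3 (0.04 log units; within the scatter). None of these compounds carries bromine, so the data contain no direct precedent, and the range stays wide. An estimated 1.0-fold lower number from compound 3 to compound 4 (0.01 log units; within the scatter) is expected, meaning no step beyond the scatter. For compound 4 the estimate is 65 mL/min/kg, with an expected range of 35 mL/min/kg to 110 mL/min/kg.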

Compound 4, clearance: 43 mL/min/kg
Compound 4: middle estimate off by 1.5-fold (0.18 log units), on the high side; the range from low to high includes it.
By their numbers in this assay, from the lowest: compounds 4, 1, 3 and 2 (each within the scatter of the next).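

In this assay the 3-bromo-4-fluorophenyl group, the only one here carrying bromine, stays within the scatter of all three earlier groups on the amide-type nitrogen (a 1.6-fold lower number from compound 3 to compound 4 (0.19 log units; within the scatter)), (a 1.7-fold lower number from compound 2 to compound 4 (0.24 log units; within the scatter)), (a 1.3-fold lower number from compound 1 to compound 4 (0.11 log units; within the scatter)). Across these four compounds, this position thus takes a phenyl with two halogens without any step beyond the scatter. No measurement available here accounts for these numbers.

As far as these compounds go, whether an amine, a carboxylic acid or a longer chain on this nitrogen would give a step beyond the scatter remains open. So does the separate contribution of the bromine and the fluorine.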